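Urea terminus: pyrrolidin-1-yl exchanged for dimethylamino

This account rests on a few compounds, and the source may have more. Where it says the series, first, only, none or still open, it means among the compounds named here.

Among the compounds with values here, compound 3 `COc1ncc(-c2ccc3nc(NC(=O)N4CCCC4)nn3c2)cc1NS(=O)(=O)c1ccc(F)cc1` stands at the high end of the three numbers so far: in a functional assay on HCT-116 cells (Homo sapiens) for cytotoxicity, read by MTT assay, with a stated time of 72 h (on this read-out higher numbers stand for weaker inhibition and lower numbers for stronger inhibition), compound 3 gives 1290 nM. Compound 1 `CCCNC(=O)Nc1nc2ccc(-c3cnc(OC)c(NS(=O)(=O)c4ccc(F)cc4)c3)cn2n1` gives 150 nM and compound 2 `COc1ncc(-c2ccc3nc(NC(=O)NCCN4CCCC4)nn3c2)cc1NS(=O)(=O)c1ccc(F)cc1` gives 230 nM. The step of a 1.5-fold higher number from compound 1 to compound 2 (0.19 log units; within the scatter) is small, whereas an 8.6-fold higher number from compound 1 to compound 3 (0.93 log units; beyond the scatter) and a 5.6-fold higher number from compound 2 to compound 3 (0.75 log units; beyond the scatter) both run upward beyond the scatter; each of those two steps placed pyrrolidin-1-yl on the carbonyl carbon in place of propylamino or of (2-(pyrrolidin-1-yl)ethyl)amino. Compound 4 `COc1ncc(-c2ccc3nc(NC(=O)N(C)C)nn3c2)cc1NS(=O)(=O)c1ccc(F)cc1` differs from compound 3 as follows: dimethylamino in place of pyrrolidin-1-yl on a carbonyl carbon. Within the data shown here, the two upward steps concern the arrival of pyrrolidin-1-yl at this carbonyl carbon, not its exchange for another group of the same kind, so no measured step matches the present change directly. With nothing in the series pointing either way, the expectation in this assay is a step around the scatter with no settled direction. Compound 4 is expected at 1500 nM, estimated between 600 nM and 4000 nM. The expected step is a 1.2-fold higher number from compound 3 to compound 4 (0.07 log units; within the scatter).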

Compound 4, half-maximal inhibitory concentration: 760 nM
Estimate against measurement, compound 4: 2.0-fold (0.30 log units) above; the range from low to high includes it.
By their numbers in this assay, from the lowest: compounds 1 and 2 (each within the scatter of the next); then compounds 4 and 3 (each within the scatter of the next).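

On the carbonyl carbon, the pyrrolidin-1-yl ring is not what sets compound 3 apart: in this assay the exchange for dimethylamino gives a 1.7-fold lower number from compound 3 to compound 4 (0.23 log units; within the scatter) and stays within the scatter. The upward shift seen earlier also appears with dimethylamino, since a 3.3-fold higher number from compound 2 to compound 4 (0.52 log units; beyond the scatter) and a 5.1-fold higher number from compound 1 to compound 4 (0.70 log units; beyond the scatter) both lie beyond the scatter. The four compounds thus fall into two pairs: compounds 1 and 2, carrying propylamino and (2-(pyrrolidin-1-yl)ethyl)amino, and compounds 3 and 4, carrying pyrrolidin-1-yl and dimethylamino.

Still open, as far as these compounds go, is where methylamino, morpholin-4-yl or diethylamino on this carbonyl carbon would fall relative to these two pairs. No measurement given here explains the separation of the pairs.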